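Compound 3 to compound 4: trifluoromethoxy for fluoro

The source may report more compounds than this note shows. Statements on the series, on what has been measured and on what is new or still open speak of the compounds shown alone.

In a functional assay on HO8910 cells (Homo sapiens) for inhibition, read by MTT assay, with a stated time of 24 h, tested at 0.1 ug/mL (on this read-out lower numbers stand for less inhibition of growth and higher numbers for more inhibition of growth at the one concentration tested), compound 1 (`O=C(CCCCC1CCSS1)Nc1ccc(OC(F)(F)F)cc1`) gives 5.53%, compound 2 (`O=C(CCCCC(S)CCS)Nc1ccccc1`) gives 7.37% and compound 3 (`O=C(CCCCC(S)CCS)Nc1ccc(F)cc1`) gives 8.11%. All three numbers lie within the scatter of one another, so compound 3 stands level with the other two. Compound 4 (`O=C(CCCCC(S)CCS)Nc1ccc(OC(F)(F)F)cc1`) has trifluoromethoxy in place of fluoro on an aromatic carbon. For the measured compounds named here, the one measured step on this aromatic carbon is fluoro in place of hydrogen, a number 0.7 percentage points higher from compound 2 to compound 3 (within the scatter). Compound 1 carries trifluoromethoxy on another core and stays low at 5.53%. The expected step, a number 0.4 percentage points higher from compound 3 to compound 4 (within the scatter), therefore stays within the scatter. For compound 4 the estimate is 8.5%, with an expected range from 2% to 18%.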

Compound 4, percent growth inhibition at one concentration: "not active" (no number reported)
For compound 4 the study gives words and no number, so the estimate cannot be set against anything.
By their numbers in this assay, from the lowest: compounds 1, 2 and 3 (each within the scatter of the next).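

For the compounds shown here, compound 4 is reported in this assay only as not active, without a number, so no step from compound 3 to compound 4 can be read. The size of any trifluoromethoxy for fluoro effect on this core stays open, and nothing shown bears on the reason for this result.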